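The source may hold more compounds than are shown below. What is called first, only, known or untested is meant among the compounds shown, and "the series" means these compounds.

Compounds measured so far in a functional assay on MCF7 cells (Homo sapiens) for inhibition, read by MTT assay, with a stated time of 96 h; on this read-out higher numbers stand for weaker inhibition of growth and lower numbers for stronger inhibition of growth:
compound 1, `C=CCOC(=O)SCCCCCCNC(=O)c1cc(-c2ccncc2)n[nH]1`, gives 12600 nM.
Compound 2, `O=C(NCCCCCCS)c1cc(-c2ccc3ccccc3c2)n[nH]1`, gives only a limit of this assay, > 50000 nM.

Compound 1 thus carries the only number shown. The other value sits at the limit of > 50000 nM in this assay, at which 1 of the 2 values shown sits, which is a limit and not a number, so nothing can be said about how compound 2 compares with compound 1 beyond that.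

Compound 3, `CCCC(=O)SCCCCCCNC(=O)c1cc(-c2ccncc2)n[nH]1`, is not yet measured. It differs from compound 1 in one place: propyl in place of allyloxy on a carbonyl carbon. Among the compounds with values here, no pair of measured compounds with a single difference between them is available, so there is no measured step to lean on. The change is a small one at the far end of the chain, away from the shared core, and the expected step of a 1.1-fold lower number from compound 1 to compound 3 (0.02 log units; within the scatter) is none beyond the usual scatter. Compound 3 is therefore expected to give about 12000 nM, with a range from 5000 nM to 30000 nM.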

Compound 3, concentration for 50% growth inhibition: 12100 nM
Compound 3: the middle estimate sits 1.0-fold (0.00 log units) below what was measured; the measured number falls inside the stated range.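

Within the data shown here, this is the first single change that can be read: propyl in place of allyloxy on a carbonyl carbon gives a 1.0-fold lower number from compound 1 to compound 3 (0.02 log units; within the scatter) in this assay. The two compounds therefore cannot be told apart on this read-out. At this position, the oxygen and the double bond of allyloxy can both be lost with no difference beyond the usual scatter, so neither feature is needed here to keep this level of growth inhibition. Nothing among the data shown explains why this exchange leaves the two compounds so alike.

The compounds shown leave open whether this tolerance extends to an amine or a carboxylic acid on the same carbonyl carbon, or to a longer chain in place of propyl. One swap at one position cannot show how far that tolerance reaches.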